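A Single Stereoisomer Tested for Cytotoxicity

The source may report more compounds than this note shows. Statements on the series, on what has been measured and on what is new or still open speak of the compounds shown alone.

Compound 1 `CC1(CNc2ccc(OC(F)(F)F)cc2)CCn2cc([N+](=O)[O-])nc2O1`: in an ADME assay on MRC5 cells (Homo sapiens) for cytotoxicity, read by resazurin assay, with a stated time of 72 h (on this read-out higher numbers stand for weaker inhibition and lower numbers for stronger inhibition), compound 1 gives >= 40000 nM, which is a limit of the assay.
Compound 2 `O=C(Nc1ccc(OC(F)(F)F)cc1)OCC1CCn2cc([N+](=O)[O-])nc2O1`: in this assay compound 2 gives >= 40000 nM, again a limit.
Compound 3 `CC1(COC(=O)Nc2ccc(OC(F)(F)F)cc2)CCn2cc([N+](=O)[O-])nc2O1`: in this assay compound 3 gives >= 40000 nM, also a limit.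

Compound 3 therefore stands at the limit of >= 40000 nM in this assay, at which 3 of the 3 values shown sit, with no number of its own. Because a step that the two limits leave unreadable from compound 2 to compound 3 runs between two limits, its size is not readable. Compound 4 `C[C@]1(COC(=O)Nc2ccc(OC(F)(F)F)cc2)CCn2cc([N+](=O)[O-])nc2O1` differs from compound 3 only in that (the two compounds have the same atoms and bonds; at least one stereo element is drawn with a configuration in one of them and without one in the other: 1 of 1 stereo elements differ; a stereocentre at a saturated ring carbon is drawn without a configuration in compound 3 and R in compound 4). Among the compounds with values here, no measured step bears on a stereocentre alone; all that is known is that every compound shown sits at the same limit. No step beyond the scatter is therefore expected in this assay. Compound 4 is estimated at 40000 nM, between 20000 nM and 80000 nM, an expected step of a number no higher from compound 3 to compound 4 (the limit leaves the size open).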

Compound 4, half-maximal inhibitory concentration: >= 40000 nM
Compound 4: a limit, no number; the forecaster's own chance of this, stated with the estimate: 85%; the middle value sits exactly at the limit.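

In this assay compound 4 gives >= 40000 nM, a limit, and the step to it from compound 3 cannot be read. The compounds shown leave open whether the drawn configuration changes cytotoxicity at all.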